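Replacing Butylsulfanyl with Nitro on the Aromatic Ring

The source may hold more compounds than are shown below. What is called first, only, known or untested is meant among the compounds shown, and "the series" means these compounds.

Of the compounds shown here, three sharing one core have been measured. Compound 1 `CC(C(=O)NCc1ccc(C(F)(F)F)cc1N1CCCCCC1)c1ccc(NS(C)(=O)=O)c(F)c1` gives 1.6 nM in an assay on CHO cells for antagonist activity at transient receptor potential cation channel subfamily V member 1 (Homo sapiens), read by FLIPR; on this read-out higher numbers stand for weaker inhibition and lower numbers for stronger inhibition; compound 2 `CC(C(=O)NCc1ccc(C(F)(F)F)cc1OC1CCCC1)c1ccc(NS(C)(=O)=O)c(F)c1` gives 0.6 nM; compound 3 `CCCCSc1cc(C(F)(F)F)ccc1CNC(=O)C(C)c1ccc(NS(C)(=O)=O)c(F)c1` gives 1.9 nM, the highest of the three numbers, although its gap to compound 1 lies within the scatter. The untested compound 4 `CC(C(=O)NCc1ccc(C(F)(F)F)cc1[N+](=O)[O-])c1ccc(NS(C)(=O)=O)c(F)c1` differs from compound 3 in one place: nitro in place of butylsulfanyl on an aromatic carbon. The measured steps that bear on this position are a 1.2-fold higher number from compound 1 to compound 3 (0.07 log units; within the scatter) and a 3.2-fold higher number from compound 2 to compound 3 (0.50 log units; beyond the scatter), so exchanging the group on this aromatic carbon has so far moved the number only modestly. Nitro itself has not been tried, so a modest step is expected, most likely upward, estimated as a 3.2-fold higher number from compound 3 to compound 4 (0.50 log units; beyond the scatter). Compound 4 is therefore expected to give about 6 nM, within a range from 1.5 nM to 25 nM.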

Compound 4, inhibition constant: "not active" (no number reported)
Compound 4 has no reported number here; there is nothing to compare the estimate with.
By their numbers in this assay, from the lowest: compound 2; then compounds 1 and 3 (each within the scatter of the next).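

In this assay, among these compounds, compound 4 is reported as "not active" without a number, so no step from compound 3 can be read. Nothing shown here explains this result. As far as these compounds go, how far nitro shifts the number on this aromatic carbon stays open.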